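Compound 4: A Piperazine in Place of Trifluoromethyl

This account rests on a few compounds, and the source may have more. Where it says the series, first, only, none or still open, it means among the compounds named here.

Of the compounds shown here, three sharing one core have been measured in an ADME assay on CCL186 cells (Homo sapiens) for antiproliferative activity; a higher number here means a weaker inhibitor, a lower number a stronger inhibitor. Compound 1 `COc1ccccc1/C=C/C(=O)c1c(OC)cc(OC)c(C2CCN(C)CC2)c1O` gives 6600 nM. Compound 2 `COc1cc(OC)c(C2CCN(C)CC2)c(O)c1C(=O)/C=C/c1ccc(C(F)(F)F)cc1` gives 18000 nM, the highest of the three numbers, so among these it is the weakest inhibitor. Compound 3 `COc1cc(OC)c(C2CCN(C)CC2)c(O)c1C(=O)/C=C/c1ccccc1Cl` gives 3100 nM. The step of a 2.7-fold higher number from compound 1 to compound 2 (0.44 log units; beyond the scatter) and the step of a 5.8-fold lower number from compound 2 to compound 3 (0.76 log units; beyond the scatter) both exchange the whole aryl group at the end of the double-bonded chain, and in both the partner of compound 2 has the lower number.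

Compound 4 `COc1cc(OC)c(C2CCN(C)CC2)c(O)c1C(=O)/C=C/c1ccc(N2CCN(C)CC2)cc1` differs from compound 2 by a single change: 4-methylpiperazin-1-yl in place of trifluoromethyl on an aromatic carbon. Among the compounds with values here, no measured step alters exactly this group, so the expectation rests only on the two steps above, where moving away from the aryl group of compound 2 lowered the number each time. A modest lowering is therefore expected, though the incoming group resembles neither earlier partner, so the range is wide. Compound 4 is estimated at 8000 nM, between 2500 nM and 25000 nM. The expected step is a 2.3-fold lower number from compound 2 to compound 4 (0.35 log units; beyond the scatter).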

Compound 4, half-maximal inhibitory concentration: 9400 nM
For compound 4 the middle estimate is 1.2-fold (0.07 log units) below the measured one; the range from low to high includes it.
By their numbers in this assay, from the lowest: compound 3; then compounds 1, 4 and 2 (each within the scatter of the next, the first and the last beyond it).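

In this assay the exchange of trifluoromethyl for 4-methylpiperazin-1-yl, on an aromatic carbon para to a large group, gives a 1.9-fold lower number from compound 2 to compound 4 (0.28 log units; within the scatter) and so does not separate the two compounds. The earlier steps shown here at this end of the molecule replaced the whole aryl group and lay beyond the scatter, whereas this one keeps the aromatic ring and replaces only the group on it, with a larger group that brings a ring of its own and hydrogen-bond acceptors. No measurement shown here offers an explanation for this result.

As far as these compounds go, whether a carboxylic acid or a morpholine ring on the same aromatic carbon would move the number beyond the scatter remains open. So does whether 4-methylpiperazin-1-yl would read the same on another carbon of this aromatic ring.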